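The source may report more compounds than this note shows. Statements on the series, on what has been measured and on what is new or still open speak of the compounds shown alone.

The shared core appears bare in compound 3 `c1ccc2c(c1)CCC2c1ncc[nH]1`. In a functional assay on CHO cells for agonist activity at Alpha-1B adrenergic receptor (Homo sapiens), read by FLIPR and calcium flux (a higher number here means that more compound is needed for the effect, a lower number that less compound is needed), compound 3 returns only a limit of the assay, > 10000 nM. Two substituted analogues frame it. Compound 1 `Cc1n[nH]cc1-c1cccc2c1CCC2c1ncc[nH]1` carries a 3-methyl-1H-pyrazol-4-yl group on an aromatic carbon, and in this assay compound 1 gives 902 nM. Compound 2 `CCCS(=O)(=O)Nc1cccc2c1CCC2c1ncc[nH]1` carries a (propylsulfonyl)amino group on an aromatic carbon. In this assay compound 2 also returns only a limit, > 10000 nM. Of the measured steps, an at least 11-fold higher number from compound 1 to compound 3 (1.04 log units; beyond the scatter) and an at least 11-fold higher number from compound 1 to compound 2 (1.04 log units; beyond the scatter), whereas a step that the two limits leave unreadable from compound 2 to compound 3. Two of the three values rest at the limit of > 10000 nM in this assay, at which 2 of the 3 values shown sit.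

Compound 4 `c1cc(-c2ncco2)c2c(c1)C(c1ncc[nH]1)CC2` has not yet been measured in this assay; it differs from compound 3 by 1,3-oxazol-2-yl in place of hydrogen on an aromatic carbon. For the measured compounds named here, the entering group, like the one in compound 1, is a five-membered aromatic ring, and compound 1 gave 902 nM, so some gain over the bare core is expected, though compound 2 shows that not every added group produces one. The step from compound 3 to compound 4 is therefore expected to be an at least 3.3-fold lower number from compound 3 to compound 4 (0.52 log units; beyond the scatter). Compound 4 is estimated at 3000 nM, within a range from 700 nM to 10000 nM.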

Compound 4, half-maximal effective concentration: > 10000 nM
Compound 4 was reported as a limit (the forecaster's own chance of this, stated with the estimate: 45%); at least 3.3-fold (0.52 log units) between middle value and limit.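

Exchanging 3-methyl-1H-pyrazol-4-yl for 1,3-oxazol-2-yl on this aromatic carbon gives an at least 11-fold higher number from compound 1 to compound 4 (1.04 log units; beyond the scatter), so a five-membered aromatic ring there does not by itself give a measurable value in this assay. Among the groups shown at this position, only 3-methyl-1H-pyrazol-4-yl gives a number rather than a limit, which ties the effect to that particular group and not to five-membered aromatic rings in general. Compound 4 returns only a limit, so its steps to compound 2 and compound 3 cannot be read: the limit of > 10000 nM in this assay, at which 3 of the 4 values shown sit.

The compounds shown leave open whether the methyl of the pyrazole matters, since they do not separate it from the ring. As far as these compounds go, how a 1H-pyrazol-4-yl group without that methyl, a methyl-bearing oxazole, or a simple amine on this aromatic carbon would read in this assay also remains open.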